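The compounds below may be only part of what the source reports. "The series", "measured", "known", "first", "only" and "open" are said of these compounds alone.

Compound 1 `Cc1cc(C#N)cc(C)c1Oc1nc(Nc2ccc(C#N)cc2)ncc1-c1cccs1` carries thiophen-2-yl on an aromatic carbon of a six-membered aromatic ring with 2 nitrogen, and in an ADME assay on MT4 cells (Homo sapiens) for cytotoxicity, read by MTT assay, with a stated time of 5 days (a lower number here means that less compound is tolerated, a higher number that more compound is tolerated), compound 1 gives 6430 nM. Compound 3 `Cc1cc(C#N)cc(C)c1Oc1nc(Nc2ccc(C#N)cc2)ncc1-c1ccsc1` carries thiophen-3-yl there; in this assay compound 3 gives 3920 nM, the lowest of the two numbers, and the step of a 1.6-fold lower number from compound 1 to compound 3 (0.21 log units; within the scatter) is within the scatter. Compound 2 `Cc1cc(C#N)cc(C)c1Oc1nc(Nc2ccc(C#N)cc2)ncc1-c1ccc(-c2ccccc2)cc1` carries 4-phenylphenyl, and in this assay compound 2 reaches only a limit, > 253000 nM. The steps of an at least 39-fold higher number from compound 1 to compound 2 (1.59 log units; beyond the scatter) and an at least 64-fold lower number from compound 2 to compound 3 (1.80 log units; beyond the scatter) are large. Compound 4 `Cc1cc(C#N)cc(C)c1Oc1nc(Nc2ccc(C#N)cc2)ncc1-c1ccc(F)cc1` differs from compound 3 by 4-fluorophenyl in place of thiophen-3-yl on an aromatic carbon. Since 4-fluorophenyl is a six-membered ring of carbon only, smaller than 4-phenylphenyl, a moderate rise is expected in this assay, a 3.1-fold higher number from compound 3 to compound 4 (0.49 log units; beyond the scatter). Compound 4 is expected to give 12000 nM, between 4000 nM and 60000 nM.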

Compound 4, half-maximal cytotoxic concentration: 42700 nM
The estimate for compound 4 lay 3.6-fold (0.55 log units) below the measured number, within the range that was stated.
By their numbers in this assay, from the lowest: compounds 3 and 1 (each within the scatter of the next); then compound 4. At a limit, above all of these: compound 2.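

In this assay, 4-fluorophenyl on this aromatic carbon stands clearly apart from both thiophene rings, with an 11-fold higher number from compound 3 to compound 4 (1.04 log units; beyond the scatter) and a 6.6-fold higher number from compound 1 to compound 4 (0.82 log units; beyond the scatter), so a large shift here does not require the second ring of 4-phenylphenyl. The outer group still matters, with an at least 5.9-fold lower number from compound 2 to compound 4 (0.77 log units; beyond the scatter). Compound 2 gives a limit rather than a number, so the full size of that step stays unknown: the limit of > 253000 nM in this assay, at which 1 of the 4 values shown sits.

The compounds shown cannot separate the effect of the six-membered ring from that of its fluoro group. On these data alone, whether a plain phenyl, a pyridine ring or an amine on this carbon would sit with the thiophene compounds or with compound 4 also remains open.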